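This account rests on a few compounds, and the source may have more. Where it says the series, first, only, none or still open, it means among the compounds named here.

Compound 1 `CC(C)n1[nH]c2ccccc2c1=O` stands as the lower of the two numbers measured in an assay on isolated protein (urine) for inhibition of Myeloperoxidase (Homo sapiens), read by spectrophotometry (a lower number here means a stronger inhibitor, a higher number a weaker inhibitor), where compound 1 gives 660 nM. Among the compounds with values here, its only measured neighbour is compound 2 `O=c1c2ccccc2[nH]n1CCCO`, which in this assay gives 1950 nM; the step of a 3.0-fold higher number from compound 1 to compound 2 (0.47 log units; beyond the scatter) is the one comparison on record, and it moves beyond the scatter when the substituent on the aromatic nitrogen is exchanged.

Compound 3 `CC(=O)OCC(C)n1[nH]c2ccccc2c1=O` is not yet measured. It differs from compound 1 by acetoxy in place of hydrogen on a saturated chain carbon, two bonds along the chain from an aromatic nitrogen; the chain on the aromatic nitrogen is kept, and the acetoxy group is appended at its end.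

The measured step bearing on this is a 3.0-fold higher number from compound 1 to compound 2 (0.47 log units; beyond the scatter), in which enlarging and functionalising the group on that nitrogen gave a modestly weaker inhibitor. Compound 3 adds two acceptor atoms in a comparable region, so a modest move in the same direction is expected, though the bearing of that single step is indirect. The expected step is therefore a 2.0-fold higher number from compound 1 to compound 3 (0.29 log units; within the scatter), and compound 3 is estimated at 1300 nM, within a range from 500 nM to 3500 nM.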

Compound 3, half-maximal inhibitory concentration: 2120 nM
Beside the measured number, compound 3's estimate is 1.6-fold (0.21 log units) below it; the measured number falls inside the stated range.
By their numbers in this assay, from the lowest: compound 1; then compounds 2 and 3 (each within the scatter of the next).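

In this assay, acetoxy in place of hydrogen on a saturated chain carbon, two bonds along the chain from an aromatic nitrogen, gives a 3.2-fold higher number from compound 1 to compound 3 (0.51 log units; beyond the scatter) and so marks a weaker inhibitor. The earlier comparison, a 3.0-fold higher number from compound 1 to compound 2 (0.47 log units; beyond the scatter), exchanged the whole isopropyl group on the aromatic nitrogen, whereas this change keeps that chain and extends it, turning one methyl into acetoxymethyl, and the number still rises beyond the scatter; among the compounds shown, both changes to the group on this nitrogen therefore move away from compound 1 in the same direction, and neither improves on it. The information available offers no explanation for this rise.

From the compounds shown here alone, whether the rise belongs to the acetoxy group itself or would follow from other groups at this carbon remains open, as a hydroxyl group, a methoxy group or a longer alkyl chain could give a different result. Going by these compounds, it also remains open whether an amine or a carboxylic acid at the end of the chain would move the number in the same direction or the opposite one.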